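Benzyloxy versus hydrogen on the pendant ring

This account rests on a few compounds, and the source may have more. Where it says the series, first, only, none or still open, it means among the compounds named here.

Measured in a functional assay on MDA-MB-231 cells (Homo sapiens) for cytotoxicity, read by MTT assay, with a stated time of 24 h; a lower number here means a stronger inhibitor, a higher number a weaker inhibitor:
compound 1, `Cc1cc(O)c(C(=O)/C=C/c2ccc(Br)cc2)c(-c2ccc(OCc3ccccc3)cc2)c1C(=O)/C=C/c1ccc(Br)cc1`: 30000 nM
compound 2, `Cc1cc(O)c(C(=O)/C=C/c2ccc(OCc3ccccc3)cc2)c(-c2ccccc2)c1C(=O)/C=C/c1ccc(OCc2ccccc2)cc1`: 10000 nM
compound 3, `Cc1cc(O)c(C(=O)/C=C/c2ccc(OCc3ccccc3)cc2)c(-c2ccc(OCc3ccccc3)cc2)c1C(=O)/C=C/c1ccc(OCc2ccccc2)cc1`: 20000 nM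

Compound 1 gives the highest of the three numbers; compound 3 lies within the usual scatter of it, while compound 2 gives a lower number that lies beyond the scatter. How the core of compound 1 differs from that of compound 3 is not broken down here. From compound 3 to compound 2 the change is hydrogen in place of benzyloxy on an aromatic carbon, and the step it made was a 2.0-fold lower number from compound 3 to compound 2 (0.30 log units; within the scatter). Compound 4, `Cc1cc(O)c(C(=O)/C=C/c2ccc(Br)cc2)c(-c2ccccc2)c1C(=O)/C=C/c1ccc(Br)cc1`, arises from compound 1 by the same change, (hydrogen in place of benzyloxy on an aromatic carbon). Resting on the step seen from compound 3 to compound 2, a 2.0-fold lower number from compound 3 to compound 2 (0.30 log units; within the scatter), the expected step is a 2.0-fold lower number from compound 1 to compound 4 (0.30 log units; within the scatter). For compound 4 the estimate in this assay is 15000 nM, expected to fall between 7000 nM and 40000 nM.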

Compound 4, half-maximal inhibitory concentration: 10000 nM
The estimate for compound 4 lay 1.5-fold (0.18 log units) above the measured number, within the range that was stated.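

In this assay, hydrogen in place of benzyloxy on an aromatic carbon gave a 3.0-fold lower number from compound 1 to compound 4 (0.48 log units; beyond the scatter), and this step agrees with the earlier one: the same change on two cores in this assay, a 2.0-fold lower number (0.30 log units; within the scatter) from compound 3 to compound 2 and a 3.0-fold lower number (0.48 log units; beyond the scatter) from compound 1 to compound 4, 1.5-fold (0.18 log units) apart, within the scatter of two such steps. The change therefore carried over between the core of compound 3 and the core of compound 1, with the same direction on both and no difference in size that the scatter can separate. Within the data shown here, this rests on only two pairs, one of whose steps lies within the scatter, so it does not show that the change would carry to other cores, nor why it acts as it does.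

Going by these compounds, it remains open how an amine, a carboxylic acid or a longer chain would behave at this same place. Also open, on these data alone, is how either core would respond to a nitrile in place of the bromine of compound 4.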